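Lengthening the Ketone Chain Within a Tetrazole Series

The source may hold more compounds than are shown below. What is called first, only, known or untested is meant among the compounds shown, and "the series" means these compounds.

Of the compounds shown here, three have been measured in an assay on isolated protein for binding affinity to metabotropic glutamate receptor 2 (Homo sapiens), read by GTPgammaS binding; on this read-out lower numbers stand for an effect already at smaller amounts and higher numbers for an effect only at larger amounts of compound. Compound 1 `CCCc1c(OC(C)CCC(C)Oc2ccc(-c3nn[nH]n3)cc2)ccc(C(C)=O)c1O` gives 241 nM. Compound 2 `CCCc1c(OCCCCNc2ccc(-c3nn[nH]n3)cc2)ccc(C(C)=O)c1O` gives 939 nM. Compound 3 `CCC(=O)c1ccc(OCCCCOc2ccc(-c3nn[nH]n3)cc2)c(C)c1O` gives 380 nM, the second highest of the three numbers; its gap to compound 1 lies within the scatter, while its gap to compound 2 lies beyond it, so compound 3 sits between these two without being distinguishable from compound 1.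

Compound 4 `CCCC(=O)c1ccc(OCCCCOc2ccc(-c3nn[nH]n3)cc2)c(C)c1O` has not yet been measured. It differs from compound 3 by methyl in place of hydrogen on a saturated chain carbon, two bonds along the chain from a carbonyl carbon. No pair of measured compounds differs in exactly this way, so the size of the step is not known from the shown data. The expected change is small: a 1.2-fold lower number from compound 3 to compound 4 (0.07 log units; within the scatter) is estimated to stay within the scatter, with no clear direction. On that basis compound 4 is expected to give about 320 nM, in a range from 150 nM to 700 nM.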

Compound 4, half-maximal effective concentration: 304 nM
Beside the measured number, compound 4's estimate is 1.1-fold (0.02 log units) above it, and the stated range covers the measured number.
By their numbers in this assay, from the lowest: compounds 1, 4 and 3 (each within the scatter of the next); then compound 2.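

Replacing propanoyl with propylcarbonyl, which puts methyl in place of hydrogen on a saturated chain carbon, two bonds along the chain from a carbonyl carbon, gives a 1.3-fold lower number from compound 3 to compound 4 (0.10 log units; within the scatter) in this assay. For the compounds shown here, this is the first direct reading of this change at this position, and on this read-out it leaves compound 3 and compound 4 indistinguishable, so the added carbon has no effect that can be resolved here. No other measurement is available to explain this result.

This single step cannot show whether the chain can grow further, for example to a pentanoyl group, or whether an amine or a carboxylic acid at its end would be accepted equally well. It also leaves open whether the same change would read alike on the core of compound 1.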